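Replacing the acetyl on the ring nitrogen with 2-fluorophenyl

The source may report more compounds than this note shows. Statements on the series, on what has been measured and on what is new or still open speak of the compounds shown alone.

The series shares one core; compound 1 `N#Cc1ccc(Nc2nc(Oc3ccnc4ccccc34)nc(N3CCN(C(c4ccccc4)c4ccc(Cl)cc4)CC3)n2)cc1C(F)(F)F`, compound 2 `CC(=O)N1CCN(c2nc(Nc3ccc(C#N)c(C(F)(F)F)c3)nc(Oc3ccnc4ccccc34)n2)CC1` and compound 3 `N#Cc1ccc(Nc2nc(Oc3ccnc4ccccc34)nc(N3CCN(c4ncccn4)CC3)n2)cc1C(F)(F)F` differ only in the group on an amine nitrogen in a ring. In a functional assay on DU-145 cells (Homo sapiens) for cytotoxicity, read by sulforhodamine B assay, with a stated time of 48 h (a lower number here means a stronger inhibitor of growth, a higher number a weaker inhibitor of growth), compound 1 gives > 100000 nM, which is a limit of the assay rather than a number. Compound 2 gives > 100000 nM in this assay, again a limit. Compound 3 gives > 100000 nM in this assay, also a limit. Compound 2 therefore stands at the limit, and the step that the two limits leave unreadable from compound 2 to compound 3 cannot be sized. All three values sit at the limit of > 100000 nM in this assay, at which 3 of the 3 values shown sit.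

Compound 4 `N#Cc1ccc(Nc2nc(Oc3ccnc4ccccc34)nc(N3CCN(c4ccccc4F)CC3)n2)cc1C(F)(F)F` carries the change (2-fluorophenyl in place of acetyl on an amine nitrogen in a ring). For the measured compounds named here, no measured step bears on this change in a readable way, since a step that the two limits leave unreadable from compound 2 to compound 3 is the only one and it runs between two limits. The expectation rests on the three values alone: compound 4 is expected to remain near the limit, and the step is estimated as a number no higher from compound 2 to compound 4 (the limit leaves the size open). Compound 4 is thus estimated at 100000 nM, with a range from 30000 nM to 300000 nM in this assay.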

Compound 4, concentration for total growth inhibition: > 100000 nM
Compound 4: a limit, no number; the forecaster's own chance of this, stated with the estimate: 80%; the middle value lies on the limit itself.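

In this assay, for the compounds shown here, compound 4 gives > 100000 nM, a limit and not a number, so no step from compound 2 or compound 3 to compound 4 can be read. The compounds shown leave open whether any group on this ring nitrogen gives a readable value: the limit of > 100000 nM in this assay, at which 4 of the 4 values shown sit.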